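An Indole Replaces a Bromothiophene on the Carbonyl Carbon

A few compounds are considered here, and "the series" means these few. Any claim that something is new, unique, unknown or untested is made for them only; others in the source may bear on it.

Compound 1 `COc1ccc(-c2cc3ccccc3nc2/C=C/C(=O)c2ccc(F)cc2)cc1` gives 5450 nM in a functional assay on MCF7 cells (Homo sapiens) for antiproliferative activity, read by XTT assay, with a stated time of 72 h; a lower number here means a stronger inhibitor, a higher number a weaker inhibitor.
Compound 2 `COc1ccc(-c2cc3ccccc3nc2/C=C/C(=O)c2ccc(Br)s2)cc1` gives 910 nM in this assay.

For the measured compounds named here, of the two measured compounds, compound 2 shows the lower number; its only neighbour, compound 1, stands apart by a 6.0-fold lower number from compound 1 to compound 2 (0.78 log units; beyond the scatter), a step that swapped the group on the carbonyl carbon. Compound 3 `COc1ccc(-c2cc3ccccc3nc2/C=C/C(=O)c2c[nH]c3ccccc23)cc1` is the next variation at that same place: 1H-indol-3-yl in place of 5-bromothiophen-2-yl on a carbonyl carbon. Going by the values given here, the single measured step bearing on this position, a 6.0-fold lower number from compound 1 to compound 2 (0.78 log units; beyond the scatter), was beyond the scatter, so what sits on the carbonyl carbon plainly matters here. Among the compounds with values here, no measured compound carries an indole, so the direction of this step is open. The expectation for compound 3 is a number close to that of compound 2, perhaps a little lower, with wide uncertainty. Compound 3 is therefore estimated at 700 nM, within a range from 120 nM to 4000 nM. That estimate corresponds to an expected step of a 1.3-fold lower number from compound 2 to compound 3 (0.11 log units; within the scatter).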

Compound 3, half-maximal inhibitory concentration: > 10000 nM
Compound 3: a limit, no number (the forecaster's own chance of this, stated with the estimate: 5%); at least 14-fold (1.15 log units) between middle value and limit.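

Compound 3 gives a limit of the assay, not a number: the limit of > 10000 nM in this assay, at which 1 of the 3 values shown sits. The change to 1H-indol-3-yl on the carbonyl carbon brings an at least 10-fold higher number from compound 2 to compound 3 (1.04 log units; beyond the scatter), so this place does not take every aromatic ring equally, even though both groups hold a five-membered aromatic ring with 1 hetero atom. The comparison with 4-fluorophenyl gives an at least 1.8-fold higher number from compound 1 to compound 3 (0.26 log units; that floor lies within the scatter), and since that floor lies within the scatter, it does not settle whether compound 3 truly sits apart from compound 1.

The change alters several things at once, so the compounds shown leave open whether the added six-membered ring, the hydrogen-bond donor or the lost bromine accounts for the step. A plain thiophen-2-yl group and a 1-methylindol-3-yl group on the carbonyl carbon would help pull these apart.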